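A Piperazine Swap in a Flat Series

The compounds below may be only part of what the source reports. "The series", "measured", "known", "first", "only" and "open" are said of these compounds alone.

- Compound 1 `N#Cc1c(O)nc(SCc2nc3ccccc3[nH]2)nc1-c1ccccc1`: 3.28 nM
- Compound 2 `N#Cc1c(Nc2ccccc2)nc(SCc2nc3ccccc3[nH]2)nc1-c1ccccc1`: 3.28 nM
- Compound 3 `N#Cc1c(NC(N)=O)nc(SCc2nc3ccccc3[nH]2)nc1-c1ccccc1`: 3.37 nM

In a functional assay on U-937 cells (Homo sapiens) for cytotoxicity, read by MTT assay, with a stated time of 3 days (on this read-out higher numbers stand for weaker inhibition and lower numbers for stronger inhibition), compound 3 gives 3.37 nM, which lies within the scatter of the other two values. Compound 4 `N#Cc1c(-c2ccccc2)nc(SCc2nc3ccccc3[nH]2)nc1N1CCNCC1` is still unmeasured. It carries piperazin-1-yl in place of ureido on an aromatic carbon. The measured steps at this same carbon are no change at the digits printed from compound 1 to compound 2 (within the scatter), a 1.0-fold higher number from compound 1 to compound 3 (0.01 log units; within the scatter) and a 1.0-fold higher number from compound 2 to compound 3 (0.01 log units; within the scatter), and all three stay within the scatter. Within the data shown here, no measured compound carries piperazin-1-yl, so this flat pattern may not extend to it, and the range is kept wide. The expected result is a 1.0-fold higher number from compound 3 to compound 4 (0.00 log units; within the scatter), with no step beyond the scatter in either direction. Compound 4 is estimated at 3.4 nM, with a range of 1.7 nM to 7 nM.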

Compound 4, half-maximal inhibitory concentration: 5.81 nM
Beside the measured number, compound 4's estimate is 1.7-fold (0.23 log units) below it, within the range that was stated.
By their numbers in this assay, from the lowest: compounds 1, 2, 3 and 4 (each within the scatter of the next).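

Putting piperazin-1-yl, a six-membered non-aromatic ring, at this aromatic carbon gives a 1.7-fold higher number from compound 3 to compound 4 (0.24 log units; within the scatter) and a 1.8-fold higher number from compound 2 to compound 4 (0.25 log units; within the scatter) and a 1.8-fold higher number from compound 1 to compound 4 (0.25 log units; within the scatter) in this assay here. The flat picture therefore reaches beyond hydroxy, anilino and ureido to a non-aromatic ring, and none of the four groups at this carbon separates from the others.

As far as these compounds go, whether a carboxylic acid or a longer alkyl chain at this carbon would stay equally flat remains open, as does the effect of changes elsewhere on the shared core. Nothing available here offers an explanation for this flat behaviour.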